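The source may hold more compounds than are shown below. What is called first, only, known or untested is meant among the compounds shown, and "the series" means these compounds.

Measured in an ADME assay on CHO cells (Cricetulus griseus) for cytotoxicity, read by LDH release (a higher number here means a weaker inhibitor, a lower number a stronger inhibitor), so far:
Compound 1 `CC(C(=O)NCc1ccc(F)cc1)S(=O)(=O)c1ccc(Cl)cc1Cl` gives "not determined" (no result reported)
Compound 2 `CC(Oc1ccc(Cl)cc1Cl)C(=O)N[C@@H](C)c1ccc(F)cc1` gives 32000 nM
Compound 3 `CC(Oc1ccc(Cl)cc1Cl)C(=O)NCc1cccc(F)c1` gives 27000 nM

Compound 3 stands level with compound 2. Their two numbers lie within the usual scatter of repeated measurements, so neither can be called the stronger inhibitor. Compound 1 adds no number to set beside them.

The next compound is compound 4 `CC(Oc1ccc(Cl)cc1Cl)C(=O)NCc1cccc(Cl)c1` which carries chloro in place of fluoro on an aromatic carbon, meta to a large group. The same difference can be read as 3-fluorophenyl to 3-chlorophenyl, and its full count is chloro in place of fluoro on an aromatic carbon with nothing else altered.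

Going by the values given here, no two measured compounds differ in one place only, so there is no direct measure of what such a swap does in this assay for this series. Among the compounds with values here, the only guide is modest. Compound 2 at 32000 nM and compound 3 at 27000 nM fall within the scatter of each other even though their structures differ in more than one place. On that basis, little change is expected, perhaps a slightly lower number. The expected size of the move is a 1.1-fold lower number from compound 3 to compound 4 (0.05 log units; within the scatter) which would stay within the scatter. For compound 4 the estimated value is 24000 nM with an expected range from 12000 nM to 45000 nM for repeated measurements.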

Compound 4, half-maximal inhibitory concentration: 19000 nM
Beside the measured number, compound 4's estimate is 1.3-fold (0.10 log units) above it; low and high end bracket the measured number.
By their numbers in this assay, from the lowest: compounds 4, 3 and 2 (each within the scatter of the next).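

In this assay, going by these compounds alone, a 1.4-fold lower number from compound 3 to compound 4 (0.15 log units; within the scatter) gives the first direct reading of a change made in one place only: chloro in place of fluoro on an aromatic carbon, meta to a large group. Within the data shown here, earlier comparisons could not isolate a single change, whereas this pair shows that going from 3-fluorophenyl to 3-chlorophenyl does not separate the two compounds beyond the usual scatter of repeated measurements, so this one swap at this position cannot be said to alter the read-out. Nothing measured here offers an explanation for this result.

From the compounds shown here alone, only two halogens have been compared at this position, so it remains open whether a group of another kind there, such as methyl, methoxy, nitrile or an amine, would give a number clearly apart from those of compound 3 and compound 4. Going by these compounds, it is also open whether a larger alteration, such as a carboxylic acid or a longer chain in place of the 3-chlorophenyl group, would move the number beyond the scatter.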